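Swapping chloro for nitro on a shared pyrimidine-ether scaffold

The source may hold more compounds than are shown below. What is called first, only, known or untested is meant among the compounds shown, and "the series" means these compounds.

Measured so far:
Compound 1 `Cc1cc(C#N)cc(C)c1Oc1ccnc(Nc2ccc(C#N)cc2)n1` gives 1.39 in a physicochemical assay for lipophilicity; a higher number here means a more lipophilic compound, a lower number a more polar compound.
Compound 2 `N#Cc1ccc(Nc2nccc(Nc3c(Cl)cc(Cl)cc3Cl)n2)cc1` gives 0.51 in this assay.
Compound 3 `Cc1cc(C#N)cc(C)c1Oc1nc(Nc2ccc(C#N)cc2)ncc1Cl` gives 1.29 in this assay.

Compound 3 stands second highest of these three numbers. Its nearest neighbour is compound 1, whose value sits slightly higher but within the scatter, so the two cannot be told apart. Compound 2 lies furthest away, well below compound 3 and beyond the scatter.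

Compound 4 `Cc1cc(C#N)cc(C)c1Oc1nc(Nc2ccc(C#N)cc2)ncc1[N+](=O)[O-]` has not yet been measured. It differs from compound 3 in one place: nitro in place of chloro on an aromatic carbon. Going by the values given here, the only measured step that bears on this position is a number 0.10 log units lower from compound 1 to compound 3 (within the scatter), which shows that putting chloro at this carbon hardly moved the number. Among the compounds with values here, no measured pair here shows what a nitro group does in this assay, so the expectation for the entering group rests on general experience rather than on these compounds.

For compound 4 a clear drop in this assay is expected, a step of about a number 0.74 log units lower from compound 3 to compound 4 (beyond the scatter) from compound 3. The estimate for compound 4 is therefore 0.55, with a likely range from 0.1 to 1.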

Compound 4, partition coefficient: 0.7
Compound 4: middle estimate off by 0.15 log units, on the low side; low and high end bracket the measured number.
By their numbers in this assay, from the lowest: compounds 2 and 4 (each within the scatter of the next); then compounds 3 and 1 (each within the scatter of the next).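

At this carbon of the shared core, the identity of the group matters in this assay: chloro could not be told apart from hydrogen, whereas nitro clearly can be told apart from both, with the change from chloro giving a number 0.59 log units lower from compound 3 to compound 4 (beyond the scatter) and the change from hydrogen giving a number 0.69 log units lower from compound 1 to compound 4 (beyond the scatter). Going by these compounds alone, the position is therefore not indifferent to what sits on it, and the earlier pair alone could not show this, since its only step stayed within the scatter. No measurement shown here explains why nitro parts from chloro and hydrogen at this carbon, so the result stands as an observation on these compounds alone.

From the compounds shown here alone, it remains open whether other groups at this carbon, such as an amine, a carboxylic acid or a methoxy group, would stay with hydrogen and chloro or move the number as nitro does. Going by these compounds, it is also open whether nitro would give a step of similar size on the core of compound 2, which differs from compound 1 in its ether side.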